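A few compounds are considered here, and "the series" means these few. Any claim that something is new, unique, unknown or untested is made for them only; others in the source may bear on it.

The measured compounds in an ADME assay on MT4 cells (Homo sapiens) for cytotoxicity, read by MTT assay, with a stated time of 96 h; on this read-out higher numbers stand for lower toxicity in this test and lower numbers for higher toxicity in this test:

Compound 1 `Fc1ccc(-c2nc3cc(C(F)(F)F)ccc3[nH]2)cc1` gives 22000 nM.
Compound 2 `COc1ccc(-c2nc3cc([N+](=O)[O-])ccc3[nH]2)c(OC)c1` reaches only the limit of this test, > 100000 nM.

Going by the values given here, compound 1 thus holds the only actual number in this assay; the one other value shown is a limit rather than a number, so no measured step stands beside compound 1. Compound 3 `O=[N+]([O-])c1ccc(-c2nc3cc(C(F)(F)F)ccc3[nH]2)cc1` differs from compound 1 in a single place: nitro in place of fluoro on an aromatic carbon. Compound 2 also carries a nitro group, but the rest of its structure differs too, so its limit alone cannot say what this change on compound 1 will do. For this assay I expect a small step, within the scatter or a little toward lower toxicity. The expected step is a 1.4-fold higher number from compound 1 to compound 3 (0.13 log units; within the scatter). Compound 3 is therefore estimated at about 30000 nM, with a likely range from 8000 nM to 100000 nM.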

Compound 3, half-maximal cytotoxic concentration: 6000 nM
Estimate against measurement, compound 3: 5.0-fold (0.70 log units) above; the whole stated range lies above it.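

On the core of compound 1, the aromatic carbon para to a large group responds to a change of group: nitro in place of fluoro gives a 3.7-fold lower number from compound 1 to compound 3 (0.56 log units; beyond the scatter) in this assay, which means higher toxicity in this test. Going by these compounds alone, this is the only measured step so far, so it gives the first direct sign that what sits at this position can alter the read-out. Compound 2 also carries a nitro group, but it differs from compound 3 in more than one place and its value is a limit, not a number: the limit of > 100000 nM in this assay, at which 1 of the 3 values shown sits.

A single step cannot show which feature of the nitro group matters, or whether other groups would move the number the same way. As far as these compounds go, how an amine or a carboxylic acid at this position would read in this assay remains open.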